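This account rests on a few compounds, and the source may have more. Where it says the series, first, only, none or still open, it means among the compounds named here.

Of the compounds shown here, three of related build have been tested in an ADME assay on MT4 cells (Homo sapiens) for cytotoxicity, read by MTT assay, with a stated time of 96 h; on this read-out higher numbers stand for lower toxicity in this test and lower numbers for higher toxicity in this test. Compound 1 `COc1ccc(-c2nc3cc(Cl)c(Cl)cc3[nH]2)cc1` gives 1000 nM. Compound 2 `COc1ccc(-c2nc3cc(Cl)c(Cl)cc3[nH]2)c([N+](=O)[O-])c1` gives 2000 nM. Compound 3 `O=[N+]([O-])c1ccc(-c2nc3ccccc3[nH]2)c([N+](=O)[O-])c1` gives 7000 nM, the highest of the three numbers; the difference between the core of compound 3 and the core of compound 2 is not broken down here.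

Compound 2 and compound 1 differ in one place: hydrogen in place of nitro on an aromatic carbon. The step was a 2.0-fold lower number from compound 2 to compound 1 (0.30 log units; within the scatter).

Compound 4 `O=[N+]([O-])c1ccccc1-c1nc2ccccc2[nH]1` is not yet measured. Against compound 3 the change is hydrogen in place of nitro on an aromatic carbon. This is the same kind of change as from compound 2 to compound 1, not the same: there the hydrogen entered ortho to a large group and meta to a methoxy group, here it enters meta to a nitro group and para to a group of 9 heavy atoms.

Resting on the step of a 2.0-fold lower number from compound 2 to compound 1 (0.30 log units; within the scatter) alone, since compound 3 gives 7000 nM and nothing else bears on this change, the expected step is a 1.8-fold lower number from compound 3 to compound 4 (0.24 log units; within the scatter). Compound 4 is therefore estimated at 4000 nM, between 1500 nM and 10000 nM.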

Compound 4, half-maximal cytotoxic concentration: 60000 nM
Beside the measured number, compound 4's estimate is 15-fold (1.18 log units) below it; measured number above the stated range.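

In this assay, putting hydrogen in place of nitro gave an 8.6-fold higher number from compound 3 to compound 4 (0.93 log units; beyond the scatter), a move toward lower toxicity in this test. The same swap therefore does not carry over as one fixed step between these cores, and the two results differ by more than repeat measurements would explain: the same change on two cores in this assay, a 2.0-fold lower number (0.30 log units; within the scatter) from compound 2 to compound 1 and an 8.6-fold higher number (0.93 log units; beyond the scatter) from compound 3 to compound 4, 17-fold (1.23 log units) apart, beyond the scatter of two such steps

Among these compounds, this rests on only one pair of compounds for each core, and the two pairs differ both in the core and in the surroundings of the nitro group that leaves, so it does not show which of these sets the size or direction of the step.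

The compounds shown leave open whether a third core would follow either pair, and what would happen if the nitro group remaining in compound 4 were also replaced by hydrogen. They also leave open how a different group in the same place, such as an amine or a carboxylic acid, would change this number on either core.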